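A Methoxymethoxy Group Added to Compound 1

The source may hold more compounds than are shown below. What is called first, only, known or untested is meant among the compounds shown, and "the series" means these compounds.

Compound 1 `O=C1OC[C@H](Cc2ccccc2)[C@H]1Cc1ccccc1` - 77000 nM
Compound 2 `CCCCOc1ccccc1C[C@H]1C(=O)OC[C@@H]1Cc1ccccc1` - 20000 nM
Compound 3 `COCOc1cccc(C[C@H]2C(=O)OC[C@@H]2Cc2ccccc2)c1` - not yet measured

Among the measured compounds shown here, in a functional assay on HL-60 cells (Homo sapiens) for cytotoxicity, read by WST assay, with a stated time of 48 h (on this read-out higher numbers stand for an effect only at larger amounts of compound and lower numbers for an effect already at smaller amounts), compound 1 gives 77000 nM as the higher of the two numbers so far. The change leading to compound 3 is methoxymethoxy in place of hydrogen on an aromatic carbon, meta to a large group (methoxymethoxy in place of hydrogen on an aromatic carbon). For the measured compounds named here, the one measured step that bears on it is butoxy in place of hydrogen on an aromatic carbon (a 3.9-fold lower number from compound 1 to compound 2 (0.59 log units; beyond the scatter)), which is modest but beyond the scatter. Butoxy is a different group and this is a single step, so only a modest move towards a lower number is expected in this assay and it may stay within the scatter. For compound 3 the estimated value is 35000 nM with an expected range from 12000 nM to 90000 nM in this measurement. This estimate means an expected small step (a 2.2-fold lower number from compound 1 to compound 3 (0.34 log units; beyond the scatter)).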

Compound 3, half-maximal effective concentration: 80000 nM
Compound 3: middle estimate off by 2.3-fold (0.36 log units), on the low side, and the stated range covers the measured number.
By their numbers in this assay, from the lowest: compound 2; then compounds 1 and 3 (each within the scatter of the next).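

A methoxymethoxy group on an aromatic carbon, meta to a large group, gives a step within the scatter in this assay (a 1.0-fold higher number from compound 1 to compound 3 (0.02 log units; within the scatter)), so the two compounds cannot be told apart on this read-out. A new group on an aromatic carbon of compound 1 therefore does not always go with a lower number, although the butoxy step did (a 3.9-fold lower number from compound 1 to compound 2 (0.59 log units; beyond the scatter)). No measurement shown here explains why these two steps differ.

From the compounds shown here alone, it stays open whether the group itself or the aromatic carbon that carries it sets the two steps apart. Going by these compounds, it also stays open how an amine, a carboxylic acid or a longer chain at this same place would read in this assay.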